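Nitro in place of methylsulfanyl: notes on compound 3

The source may report more compounds than this note shows. Statements on the series, on what has been measured and on what is new or still open speak of the compounds shown alone.

compound 1 `COc1cc(C(=O)/C=C/c2c[nH]c3ccccc23)cc([N+](=O)[O-])c1OC` gives 1390 nM
compound 2 `COc1cc(C(=O)/C=C/c2cn(C)c3ccccc23)cc(SC)c1OC` gives 210 nM

In a functional assay on HCT-8 cells (Homo sapiens) for antiproliferative activity, read by MTT assay, with a stated time of 48 h (on this read-out higher numbers stand for weaker inhibition and lower numbers for stronger inhibition), compound 2 holds the lower of the two numbers, and the gap to compound 1 lies beyond the scatter. Compound 3 `COc1cc(C(=O)/C=C/c2cn(C)c3ccccc23)cc([N+](=O)[O-])c1OC` carries nitro in place of methylsulfanyl on an aromatic carbon of compound 2 (nitro in place of methylsulfanyl on an aromatic carbon). Going by the values given here, no measured pair isolates this change. Compound 1, which also carries nitro on a core that is not identical, gives 1390 nM in this assay, so a move towards a higher number is expected. The expected step, moderate in size, is a 2.1-fold higher number from compound 2 to compound 3 (0.33 log units; beyond the scatter) in this assay. Compound 3 is estimated at 450 nM (range 120 nM to 1500 nM).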

Compound 3, half-maximal inhibitory concentration: 1660 nM
Compound 3: the middle estimate sits 3.7-fold (0.57 log units) below what was measured; the measured number lies above the stated range.
By their numbers in this assay, from the lowest: compound 2; then compounds 1 and 3 (each within the scatter of the next).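

In this assay the position on the aromatic carbon ortho to a methoxy group proves sensitive to this swap: nitro in place of methylsulfanyl gives a 7.9-fold higher number from compound 2 to compound 3 (0.90 log units; beyond the scatter). With nitro present, methyl in place of hydrogen on the aromatic nitrogen gives a 1.2-fold higher number from compound 1 to compound 3 (0.08 log units; within the scatter), so that methyl does not separate these two nitro compounds. Nothing available explains the step at the aromatic carbon.

From the compounds shown here alone, whether an amine or a nitrile at this position would fall nearer compound 2 or compound 3 stays open. Also open, going by these compounds, is whether the methyl on the aromatic nitrogen matters when methylsulfanyl is present.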